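The compounds below may be only part of what the source reports. "The series", "measured", "known", "first", "only" and "open" are said of these compounds alone.

Measured compounds:
Compound 1 `CCCn1c(=O)c(-c2ccc(C(=O)NCc3cccnc3)cc2)nc2ccc(NC(=O)CCCCCCCCCCC(=O)N[C@H](C(=O)N3C[C@@H](O)C[C@@H]3C(=O)N[C@@H](C)c3ccc(-c4scnc4C)cc3)C(C)(C)C)cc21` — 143 nM
Compound 2 `CCCn1c(=O)c(-c2ccc(C(=O)NCc3cccnc3)cc2)nc2ccccc21` — 99 nM

In a functional assay on A2780 cells (Homo sapiens) for inhibition, read by CCK-8 assay, with a stated time of 72 h (on this read-out lower numbers stand for stronger inhibition and higher numbers for weaker inhibition), compound 1 gives 143 nM. Within the data shown here, the only other measured compound, compound 2, gives 99 nM in this assay; compound 1 has the higher of the two numbers, but the gap between them lies within the usual scatter, so the two compounds cannot be told apart on these data. Among the measured compounds shown here, no step between measured compounds is given here.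

Compound 3 `CCCn1c(=O)c(-c2ccc(C(=O)NCc3cccnc3)cc2)nc2ccc(NC(=O)CCCCCCCCCCC(=O)N[C@H](C(=O)N3C[C@H](O)C[C@H]3C(=O)N[C@@H](C)c3ccc(-c4scnc4C)cc3)C(C)(C)C)cc21` is yet to be measured in this assay. It differs from compound 1 as follows: the two compounds have the same atoms and bonds and differ only in configuration as drawn: 2 of 4 stereo elements differ; a stereocentre at a saturated ring carbon is drawn S in compound 1 and R in compound 3; a stereocentre at a saturated ring carbon is drawn R in compound 1 and S in compound 3. Since compound 2, which carries only the shared core, already gives 99 nM, the large appended portion of compound 1 does not by itself move the number beyond the scatter, and a change of configuration within that portion is expected to leave the read-out in the same region, perhaps drifting toward a weaker inhibition. For compound 3 the step of a 1.7-fold higher number from compound 1 to compound 3 (0.24 log units; within the scatter) is expected to be small. Compound 3 is therefore estimated at 250 nM, with a likely range from 100 nM to 700 nM.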

Compound 3, half-maximal inhibitory concentration: 12.1 nM
Compound 3: middle estimate off by 21-fold (1.32 log units), on the high side, and the stated range ends above it.
By their numbers in this assay, from the lowest: compound 3; then compounds 2 and 1 (each within the scatter of the next).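

In this assay the change of configuration gives a 12-fold lower number from compound 1 to compound 3 (1.07 log units; beyond the scatter), a step beyond the scatter, so the drawn configuration at these two saturated ring carbons has a large bearing on the read-out. The earlier compounds shown here could not show this, as neither of them formed a pair differing in configuration alone. No atom or bond changes, so the step can be placed on the two ring stereocentres drawn S and R in compound 1 and R and S in compound 3, and on nothing else: the fact that compounds 1 and 3 differ only in the configuration as drawn

The compounds shown leave open whether one of these two ring stereocentres would carry the step by itself or whether both must change together. They also leave open how the number would respond if, with the configuration of compound 3 kept, the hydroxyl group of the appended portion gave way to an amine, or the chain linking that portion to the shared core gave way to a shorter chain.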